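Chloro for hydrogen on two fused cores, cytotoxicity

This account rests on a few compounds, and the source may have more. Where it says the series, first, only, none or still open, it means among the compounds named here.

Measured in a functional assay on OVCAR-4 cells (Homo sapiens) for cytotoxicity, read by sulforhodamine B assay, with a stated time of 48 h; a higher number here means that more compound is tolerated, a lower number that less compound is tolerated:
compound 1 `ClCc1ccc(Cn2cnc3c(Cl)ncnc32)cc1`: > 100000 nM, a limit of the assay
compound 2 `ClCc1ccccc1Cn1cnc2ncnc(Cl)c21`: 77600 nM
compound 3 `ClCc1ccc(Cn2cnc3c(Cl)nc(Cl)nc32)cc1`: 61700 nM

Compound 1 sits at the limit of > 100000 nM in this assay, at which 1 of the 3 values shown sits, so it returns no number. Compound 3 differs from compound 1 by chloro in place of hydrogen on an aromatic carbon. In this assay that change brings an at least 1.6-fold lower number from compound 1 to compound 3 (0.20 log units; that floor lies within the scatter).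

Compound 2 and compound 1 have the same atoms joined differently, and the difference between the two cores is not broken down here. Compound 2 gives 77600 nM, and compound 3 gives 61700 nM, the two lying within the usual scatter of each other.

Compound 4 `ClCc1ccccc1Cn1cnc2nc(Cl)nc(Cl)c21` stands to compound 2 as compound 3 stands to compound 1: it carries chloro in place of hydrogen on an aromatic carbon, and the place is described in the same words, so this is the same change on the other core. For compound 4 the expected step is a 1.6-fold lower number from compound 2 to compound 4 (0.19 log units; within the scatter), to be set beside an at least 1.6-fold lower number from compound 1 to compound 3 (0.20 log units; that floor lies within the scatter). That expectation rests on compound 3, whose step is an at least 1.6-fold lower number from compound 1 to compound 3 (0.20 log units; that floor lies within the scatter) and has its floor within the scatter, and on compound 2, which gives a number, 77600 nM. Compound 4 is expected in this assay at 50000 nM, within 25000 nM to 100000 nM.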

Compound 4, concentration lethal to 50% of the cells: > 100000 nM
Compound 4 was reported as a limit; the forecaster's own chance of this, stated with the estimate: 15%; middle value at least 2.0-fold (0.30 log units) from the limit.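

In this assay, compound 4 gives > 100000 nM, which is a limit of the assay and not a number. From the compounds shown here alone, for chloro in place of hydrogen on an aromatic carbon, the new step is an at least 1.2-fold higher number from compound 2 to compound 4 (0.11 log units; that floor lies within the scatter), so the data show no step beyond the scatter on this core, and the true size of the step remains unknown. The opposite signs of the two printed floors therefore do not show that the change behaves differently on the two cores, nor do they show that it carries over unchanged from one core to the other: the same change on two cores in this assay, an at least 1.6-fold lower number (0.20 log units; that floor lies within the scatter) from compound 1 to compound 3 and an at least 1.2-fold higher number (0.11 log units; that floor lies within the scatter) from compound 2 to compound 4; the limit leaves it open whether they differ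

Going by these compounds, with compound 1 and compound 4 both reported only as limits, the series gives just two numbers in this assay, and neither pair linked by the chloro change has a number at both ends: the limit of > 100000 nM in this assay, at which 2 of the 4 values shown sit. It remains open whether a group other than chloro on the aromatic carbon between two ring nitrogen atoms, such as an amine or a methoxy group, would give numbers that could be compared across the two cores.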